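The source may report more compounds than this note shows. Statements on the series, on what has been measured and on what is new or still open speak of the compounds shown alone.

In a functional assay on C6 cells (Rattus norvegicus) for cytotoxicity, read by MTT assay, with a stated time of 24 h, tested at 6 ug/mL (on this read-out higher numbers stand for a weaker effect at the one concentration tested and lower numbers for a stronger effect), three compounds have been measured:

compound 1 `Cc1nnc(SCC(=O)N/N=c2/scc(-c3ccc(F)cc3)n2-c2ccccc2)s1` gives 74.3%;
compound 2 `COc1ccc(-c2cs/c(=N/NC(=O)CSc3nnc(C)s3)n2-c2ccccc2)cc1` gives 57.9%;
compound 3 `COc1ccc(-c2cs/c(=N/NC(=O)CSc3ncccn3)n2-c2ccccc2)cc1` gives 89.6%.

Compound 4 `O=C(CSc1ncccn1)N/N=c1/scc(-c2ccc(F)cc2)n1-c1ccccc1` has not been measured yet. It differs from compound 3 by fluoro in place of methoxy on an aromatic carbon. The same change has already been made once, from compound 2 to compound 1, where it reads (fluoro in place of methoxy on an aromatic carbon); that step was a number 16.4 percentage points higher from compound 2 to compound 1 (beyond the scatter). The two starting points differ in their cores: compound 3 is set apart from compound 2 by pyrimidin-2-yl in place of 5-methyl-1,3,4-thiadiazol-2-yl on a sulfur, a step of a number 31.7 percentage points higher from compound 2 to compound 3 (beyond the scatter), and compound 3 stands highest of the three measured numbers. The surroundings of the change are the same in both pairs, so a step of the same kind, upward, is expected, although compound 3 already sits high in this assay and leaves less room above it. The expected step is a number 7.4 percentage points higher from compound 3 to compound 4 (within the scatter), resting on the earlier step of a number 16.4 percentage points higher from compound 2 to compound 1 (beyond the scatter). For compound 4 the estimate is 97%, between 85% and 107%.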

Compound 4, a percentage reported as activity, at one concentration (the size of the read-out at that concentration, not a potency): 84%
Beside the measured number, compound 4's estimate is 13 percentage points above it, outside the stated range (below it).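

In this assay, fluoro in place of methoxy on the core of compound 3 gives a number 5.6 percentage points lower from compound 3 to compound 4 (within the scatter). The step for this change depends on which group sits on the sulfur, so it does not carry over as a fixed amount, though a single pair of cores cannot show why: the same change on two cores in this assay, a number 16.4 percentage points higher (beyond the scatter) from compound 2 to compound 1 and a number 5.6 percentage points lower (within the scatter) from compound 3 to compound 4, 22 percentage points apart, beyond the scatter of two such steps

Seen from the other side, pyrimidin-2-yl in place of 5-methyl-1,3,4-thiadiazol-2-yl gives a number 9.7 percentage points higher from compound 1 to compound 4 (within the scatter), so this step also differs between the two cores and no general rule follows from these four compounds: the same change on two cores in this assay, a number 31.7 percentage points higher (beyond the scatter) from compound 2 to compound 3 and a number 9.7 percentage points higher (within the scatter) from compound 1 to compound 4, 22 percentage points apart, beyond the scatter of two such steps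

The compounds shown leave open how a chloro or an amine would behave in place of the fluoro. They also leave open whether a pyridin-2-yl on the sulfur would follow either pattern.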